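This account rests on a few compounds, and the source may have more. Where it says the series, first, only, none or still open, it means among the compounds named here.

Measured compounds: compound 1 `O=C(c1ccc(F)cc1)N1CCCC[C@@H]1c1nc(-c2cccc(F)c2)no1` gives 23000 nM; compound 2 `O=C(c1ccc(F)cc1F)N1CCCC[C@@H]1c1nc(-c2cccc(F)c2)no1` gives 2900 nM; compound 3 `O=C(c1ccc(F)cc1)N1CCCC1c1nc(-c2cccc(F)c2)no1` gives 3600 nM, all in an in vitro functional assay on HEK293-A cells for positive allosteric modulation of metabotropic glutamate receptor 5 (Homo sapiens), read by fluorescence and calcium flux, with a stated time of 140 s; a higher number here means that more compound is needed for the effect, a lower number that less compound is needed.

Compound 1 and compound 3 share most of their structure, but how their two cores differ is not broken down here. Compound 2 arises from compound 1 by fluoro in place of hydrogen on an aromatic carbon, a change that made the step of a 7.9-fold lower number from compound 1 to compound 2 (0.90 log units; beyond the scatter) in this assay. Compound 4 `O=C(c1ccc(F)cc1F)N1CCCC1c1nc(-c2cccc(F)c2)no1` arises from compound 3 by the same change, (fluoro in place of hydrogen on an aromatic carbon), made at a place described in the same words. As far as these compounds go, whether the new core responds in the same way is unknown, and compound 3 already sits near compound 2, so a somewhat smaller step is expected: a 5.1-fold lower number from compound 3 to compound 4 (0.71 log units; beyond the scatter), resting on the step from compound 1 to compound 2. Compound 4 is therefore estimated at 700 nM, likely between 200 nM and 2500 nM.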

Compound 4, half-maximal effective concentration: 10000 nM
The estimate for compound 4 lay 14-fold (1.15 log units) below the measured number; measured number outside the range, above it.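

The change from 4-fluorophenyl to 2,4-difluorophenyl brought a 2.8-fold higher number from compound 3 to compound 4 (0.44 log units; beyond the scatter) and so did not repeat the gain seen on the core of compound 1. The two steps run in opposite directions: the same change on two cores in this assay, a 7.9-fold lower number (0.90 log units; beyond the scatter) from compound 1 to compound 2 and a 2.8-fold higher number (0.44 log units; beyond the scatter) from compound 3 to compound 4, 22-fold (1.34 log units) apart, beyond the scatter of two such steps. This shows that in these two pairs the outcome of the change depends on the core that carries it, so a result on one core cannot simply be carried to the other, but two pairs do not show why this happens or how a further core would respond.

As far as these compounds go, it remains open whether a chloro or a methyl in the same place would follow the fluoro on each core. The compounds shown also leave open what a fluoro elsewhere on this ring would do.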